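Chain extension in anilide sulfonate esters: expected antiproliferative shift

This account rests on a few compounds, and the source may have more. Where it says the series, first, only, none or still open, it means among the compounds named here.

Measured compounds:
Compound 1, `CC(=O)Nc1cccc(S(=O)(=O)Oc2ccccc2C(C)C)c1`: 21000 nM
Compound 2, `CCCC(=O)Nc1cccc(S(=O)(=O)Oc2ccccc2C(C)C)c1`: 9400 nM
Compound 3, `CCCC(=O)Nc1ccc(S(=O)(=O)Oc2ccccc2C(C)C)cc1`: 6600 nM

In a functional assay on MCF7 cells (Homo sapiens) for antiproliferative activity, read by sulforhodamine B assay, with a stated time of 48 h (a lower number here means a stronger inhibitor, a higher number a weaker inhibitor), compound 1 gives 21000 nM, while compound 2 gives 9400 nM. The change between them is ethyl in place of hydrogen on a saturated chain carbon bound to a carbonyl carbon and it made a step of a 2.2-fold lower number from compound 1 to compound 2 (0.35 log units; beyond the scatter). Compound 3 carries a different core; how the core of compound 3 differs from the core of compound 1 is not broken down here. In this assay compound 3 gives 6600 nM, a value that lies within the scatter of compound 2 and beyond the scatter of compound 1.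

Compound 4, `CCCCCC(=O)Nc1ccc(S(=O)(=O)Oc2ccccc2C(C)C)cc1`, has not yet been measured. It differs from compound 3 by ethyl in place of hydrogen on a saturated chain carbon, three bonds along the chain from a carbonyl carbon. This is the same kind of change as that from compound 1 to compound 2, but the place differs: there the ethyl entered on a saturated chain carbon bound to a carbonyl carbon, whereas here it enters on a saturated chain carbon three bonds along the chain from a carbonyl carbon. Among the compounds shown this change occurs only twice, so the expectation rests on a single measured step.

For compound 4 a step of a 1.7-fold lower number from compound 3 to compound 4 (0.22 log units; within the scatter) in this assay is expected, because the earlier step of a 2.2-fold lower number from compound 1 to compound 2 (0.35 log units; beyond the scatter) was modest and the present change is of the same kind, set further out on the chain. The estimated value for compound 4 is therefore 4000 nM, with a range from 1500 nM to 10000 nM.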

Compound 4, half-maximal inhibitory concentration: 5300 nM
For compound 4 the middle estimate is 1.3-fold (0.12 log units) below the measured one, within the range that was stated.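

In this assay, within the data shown here, the ethyl-for-hydrogen change on the core of compound 3 gave a 1.2-fold lower number from compound 3 to compound 4 (0.10 log units; within the scatter), and the two steps seen with this change cannot be told apart: the same change on two cores in this assay, a 2.2-fold lower number (0.35 log units; beyond the scatter) from compound 1 to compound 2 and a 1.2-fold lower number (0.10 log units; within the scatter) from compound 3 to compound 4, 1.8-fold (0.25 log units) apart, within the scatter of two such steps The change can therefore be said to carry over between the two cores only in a limited sense: nothing here separates the size of its effect on one core from its effect on the other, although only the step on the core of compound 1 stands clear of the scatter. Among these compounds, this does not show that the change transfers reliably, since there are only two pairs, the ethyl enters at a different place along the chain in each, and the effects of core and place therefore cannot be separated, while the step on the core of compound 3 on its own shows no measurable gain.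

The compounds shown leave open what the chain of compound 1 would give on the core of compound 3, and what the chain of compound 4 would give on the core of compound 1, either of which would compare the same place on both cores. They also leave open how a longer chain, a branched chain, or a chain ending in an amine or a carboxylic acid would behave.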